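The source may hold more compounds than are shown below. What is called first, only, known or untested is meant among the compounds shown, and "the series" means these compounds.

Compound 1 `O=C(NCCCCc1ccccc1)c1cccc(C2SCC(=O)N2c2cccc(-c3c[nH]nn3)c2)c1` and compound 2 `COc1ccccc1N1C(=O)C(C)SC1c1cccc(C(=O)NCCCCc2ccccc2)c1` have both been tested in a physicochemical assay for solubility, read by turbidimetry, measured as kinetic solubility, at pH 6.8; a lower number here means a less soluble compound, a higher number a more soluble compound. In this assay compound 1 gives 20000 nM, and compound 2 gives 20000 nM, so the two stand level within the usual scatter. Compound 3 `O=C(NCCCCc1ccccc1)c1cccc(C2SCC(=O)N2c2cccc(F)c2)c1` has not yet been measured. It differs from compound 1 in one place: fluoro in place of 1H-1,2,3-triazol-4-yl on an aromatic carbon. Among the measured compounds shown here, no measured pair shows this exact change, so the size of the step rests on expectation alone. The step of a 2.5-fold lower number from compound 1 to compound 3 (0.40 log units; beyond the scatter) is expected to be a modest drop, roughly at the edge of the scatter. Compound 3 is therefore estimated at 8000 nM, with a range from 2000 nM to 25000 nM.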

Compound 3, solubility: 10000 nM
Estimate against measurement, compound 3: 1.3-fold (0.10 log units) below; low and high end bracket the measured number.
By their numbers in this assay, from the lowest: compounds 3, 1 and 2 (each within the scatter of the next).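

In this assay, among the compounds shown here, fluoro in place of 1H-1,2,3-triazol-4-yl on an aromatic carbon gives a 2.0-fold lower number from compound 1 to compound 3 (0.30 log units; within the scatter), the first change at this place with a measured size. The single fluorine atom therefore leaves the read-out level with that of the five-atom triazole ring, even though it carries no hydrogen-bond donor or acceptor. Nothing measured here explains this result.

As far as these compounds go, whether an amine or a carboxylic acid at this same place would also stay level remains open. So does whether the fluoro change would read the same on another compound of the series.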